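The source may report more compounds than this note shows. Statements on the series, on what has been measured and on what is new or still open speak of the compounds shown alone.

Working notes on the series. In a functional assay on A549 cells (Homo sapiens) for cytotoxicity, read by MTT assay, with a stated time of 4 days (a higher number here means a weaker inhibitor, a lower number a stronger inhibitor), compound 1 `Cc1ccc(S(=O)(=O)Oc2ccc3c(c2C)[C@H](Cn2cc(-c4ccccc4)nn2)[C@@]24CC(=O)[C@@](C)(CC[C@@H]32)C4)cc1` gives > 20000 nM, which is a limit of the assay and not a number. Compound 3 `Cc1ccc(S(=O)(=O)Oc2ccc3c(c2C)[C@H](Cn2cc(-c4ccccn4)nn2)[C@@]24CC(=O)[C@@](C)(CC[C@@H]32)C4)cc1` carries the change pyridin-2-yl in place of phenyl on an aromatic carbon relative to compound 1, and in this assay compound 3 gives > 20000 nM, again a limit. The step that the two limits leave unreadable from compound 1 to compound 3 therefore cannot be read, because the limit of > 20000 nM in this assay, at which 2 of the 3 values shown sit, leaves both ends undetermined.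

Compound 2 `C=C1C(=O)[C@]23C[C@@]1(O)CC[C@H]2c1ccc(O)c(C)c1[C@@H]3Cn1cc(-c2ccccc2)nn1` has a different core; the difference between the core of compound 1 and the core of compound 2 is not broken down here. In this assay, among the measured compounds shown here, compound 2 gives 1160 nM, the only numerical value in the set.

Compound 4 `C=C1C(=O)[C@]23C[C@@]1(O)CC[C@H]2c1ccc(O)c(C)c1[C@@H]3Cn1cc(-c2ccccn2)nn1` is not yet measured. It differs from compound 2 by pyridin-2-yl in place of phenyl on an aromatic carbon, the same change that turns compound 1 into compound 3, with the place described in identical words. Since the measured instance of this change sits between two limits, it gives no usable size for the step. The expectation for compound 4 therefore rests on compound 2 alone, whose value of 1160 nM is the starting point, with a step of a 1.3-fold higher number from compound 2 to compound 4 (0.11 log units; within the scatter) expected from compound 2 to compound 4 and a wide range allowed. For compound 4 the estimate in this assay is 1500 nM, expected to fall between 500 nM and 6000 nM.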

Compound 4, half-maximal inhibitory concentration: 1570 nM
Estimate against measurement, compound 4: 1.0-fold (0.02 log units) below, within the range that was stated.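

In this assay pyridin-2-yl in place of phenyl on an aromatic carbon gives a 1.4-fold higher number from compound 2 to compound 4 (0.13 log units; within the scatter) on the core of compound 2, so this pair cannot be told apart and the change leaves no readable mark on that core. This remains a single pair on a single core, and it does not show that the change would read the same way on any other core. The matching step on the core of compound 1 cannot be read, so the change cannot be compared across the two cores, because compound 1 and compound 3 both sit at a limit of the assay and not at a number: the limit of > 20000 nM in this assay, at which 2 of the 4 values shown sit.

Still open, from the compounds shown here alone, is how a group of another kind, such as an amine or a carboxylic acid, would read in this assay in place of phenyl on the five-membered aromatic ring with 3 nitrogen on the core of compound 2. Also open is which of the features that separate the core of compound 1 from the core of compound 2 goes with the difference in read-out, as no pair shown differs in only one of them.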